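The source may hold more compounds than are shown below. What is called first, only, known or untested is meant among the compounds shown, and "the series" means these compounds.

Working notes on a small set of cyanoaziridine ureas tested in a functional assay on WiDr cells (Homo sapiens) for inhibition; a higher number here means a weaker inhibitor, a lower number a stronger inhibitor. Compound 1 `N#CC1CN1C(=O)Nc1ccc(Cl)c(Cl)c1` carries a dichlorophenyl urea and gives 7000 nM. Compound 2 `CCCCNC(=O)N1CC1C#N`, with a butyl urea in place of the aryl urea, gives 14000 nM. Compound 3 `N#CC1CN1C(=O)Nc1ccc(F)cc1`, with a fluorophenyl urea, gives 2100 nM. Compound 3 therefore stands lowest of the three numbers in this assay; the nearest number is that of compound 1, and the gap between them lies beyond the scatter, while compound 2 stands furthest, also beyond the scatter. Whether the aryl urea or the specific halogen drives this cannot be separated on these three alone.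

Compound 4 `CCOC(=O)c1ccc(NC(=O)N2CC2C#N)cc1` has not yet been measured. It differs from compound 3 in one place: ethoxycarbonyl in place of fluoro on an aromatic carbon, the change sitting on an aromatic carbon of a six-membered aromatic ring of carbon only. For the measured compounds named here, no measured pair in this set shows what an ethoxycarbonyl in this position does; the only comparison available is between halogen-bearing aryl ureas. Given this, the expected step from compound 3 to compound 4 is a 1.3-fold higher number from compound 3 to compound 4 (0.12 log units; within the scatter), that is, none clearly beyond the scatter. For compound 4 the estimate in this assay is 2800 nM, with a range from 700 nM to 11000 nM.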

Compound 4, half-maximal inhibitory concentration: 2500 nM
For compound 4 the middle estimate is 1.1-fold (0.05 log units) above the measured one; measured number inside the range.
By their numbers in this assay, from the lowest: compounds 3 and 4 (each within the scatter of the next); then compounds 1 and 2 (each within the scatter of the next).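

In this assay, for the compounds shown here, the change to ethoxycarbonyl in place of fluoro on an aromatic carbon gives a 1.2-fold higher number from compound 3 to compound 4 (0.08 log units; within the scatter), the first step between compounds that differ in one place. At this position, para to a group of 8 heavy atoms, a single fluorine can therefore be exchanged for a group of 5 heavy atoms with 2 hydrogen-bond acceptors while the number stays within the scatter, so for this pair a halogen on the ring is not needed to hold that level. No measurement is at hand that would explain this result.

Going by these compounds, whether a carboxylic acid, an amine or a longer ester chain at the same position would also stay within the scatter of compound 3 remains open. The compounds shown also include no phenyl urea with a bare hydrogen at this position, so it remains open whether either fluoro or ethoxycarbonyl has any effect of its own on the number.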